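The source may hold more compounds than are shown below. What is called first, only, known or untested is meant among the compounds shown, and "the series" means these compounds.

Measured so far:
compound 1 `O=C1C(O)=C(C(c2ccc(F)cc2)c2c[nH]c3ccccc23)C(=O)c2ccccc21` — 28100 nM
compound 2 `COc1ccc(C(C2=C(O)C(=O)c3ccccc3C2=O)c2c[nH]c3ccccc23)cc1Br` — 11800 nM

In a functional assay on ECa-109 cells (Homo sapiens) for cytotoxicity, read by MTT assay, with a stated time of 48 h (a lower number here means a stronger inhibitor, a higher number a weaker inhibitor), compound 1 gives 28100 nM and compound 2 gives 11800 nM. Compound 2 holds the lowest of the two numbers, so it is the stronger inhibitor of the pair; its nearest neighbour is compound 1, and the step of a 2.4-fold lower number from compound 1 to compound 2 (0.38 log units; beyond the scatter) is modest but beyond the scatter. Compound 3 `O=C1C(O)=C(C(c2ccc([N+](=O)[O-])cc2)c2c[nH]c3ccccc23)C(=O)c2ccccc21` differs from compound 2 by 4-nitrophenyl in place of 3-bromo-4-methoxyphenyl on a saturated chain carbon bound to an aromatic carbon and a double-bonded ring carbon. For the measured compounds named here, the only measured step that bears on this change is a 2.4-fold lower number from compound 1 to compound 2 (0.38 log units; beyond the scatter), which exchanged one group for another at the same place; no measured compound carries a 4-nitrophenyl group, so the direction is uncertain. Because compound 1 gives 28100 nM and compound 2 gives 11800 nM, compound 3 is expected to land in or near that band, and a modest upward step a 1.7-fold higher number from compound 2 to compound 3 (0.23 log units; within the scatter) is expected. Compound 3 is estimated at 20000 nM. Its expected range runs from 7000 nM to 60000 nM.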

Compound 3, half-maximal inhibitory concentration: 60900 nM
Beside the measured number, compound 3's estimate is 3.0-fold (0.48 log units) below it, outside the stated range (above it).
By their numbers in this assay, from the lowest: compound 2; then compound 1; then compound 3.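

In this assay, the group on a saturated chain carbon bound to an aromatic carbon and a double-bonded ring carbon can also push the number up: 4-nitrophenyl in place of 3-bromo-4-methoxyphenyl gives a 5.2-fold higher number from compound 2 to compound 3 (0.71 log units; beyond the scatter). The narrower change, nitro in place of fluoro on an aromatic carbon, points the same way with a 2.2-fold higher number from compound 1 to compound 3 (0.34 log units; beyond the scatter), so compound 3 is the weakest inhibitor of the three and this place has now moved the number in both directions. Nothing measured here accounts for these shifts.

The compounds shown do not separate the bromo from the methoxy in the 3-bromo-4-methoxyphenyl group of compound 2, as the two always appear together. They also leave open how an amine or a carboxylic acid on that same ring would read.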